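A few compounds are considered here, and "the series" means these few. Any claim that something is new, unique, unknown or untested is made for them only; others in the source may bear on it.

Of the compounds shown here, three built on one shared core have been measured in a functional assay on isolated protein for inhibition of Glucose-dependent insulinotropic receptor (Rattus norvegicus), read by HTRF and cAMP accumulation; a lower number here means a smaller maximal response, a higher number a larger maximal response. Compound 1 `Cc1nc(S(C)(=O)=O)ccc1Oc1ncnc(OC2CCN(C(=O)OC(C)(C)C#N)CC2)c1F` gives 97%, compound 2 `Cc1nc(S(C)(=O)=O)ccc1Oc1ncnc(OC2CCN(C(=O)SC3CCC3)CC2)c1F` gives 81%, and compound 3 `Cc1nc(S(C)(=O)=O)ccc1Oc1ncnc(OC2CCN(C(=S)OC3(C)CC3)CC2)c1F` gives 49%, the lowest of the three. Every measured step changes only the group on the ring nitrogen: a number 16 percentage points lower from compound 1 to compound 2 (beyond the scatter), a number 48 percentage points lower from compound 1 to compound 3 (beyond the scatter) and a number 32 percentage points lower from compound 2 to compound 3 (beyond the scatter). Compound 4 `Cc1nc(S(C)(=O)=O)ccc1Oc1ncnc(OC2CCN(C(=O)c3noc(C(C)C)n3)CC2)c1F` differs from compound 3 at that same place: a group of 10 heavy atoms (6 carbon, 2 nitrogen, 2 oxygen; one five-membered aromatic ring with 3 hetero atoms) in place of a group of 7 heavy atoms (5 carbon, 1 oxygen, 1 sulfur; one three-membered non-aromatic ring of carbon only), on an amine nitrogen in a ring. Like compounds 1 and 2, compound 4 carries a carbonyl on that nitrogen rather than the thiocarbonyl of compound 3. Because a number 48 percentage points lower from compound 1 to compound 3 (beyond the scatter) and a number 32 percentage points lower from compound 2 to compound 3 (beyond the scatter) were both large, a rise back toward the values of compounds 1 and 2 is expected. The expected step is a number 36 percentage points higher from compound 3 to compound 4 (beyond the scatter) in this assay. Compound 4 is therefore estimated to give 85%, within 60% to 105%.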

Compound 4, largest response reached (reported as efficacy), in percent of the reference or control that the assay uses: 81%
Beside the measured number, compound 4's estimate is 4 percentage points above it, within the range that was stated.
By their numbers in this assay, from the lowest: compound 3; then compounds 2 and 4 (each within the scatter of the next); then compound 1.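

With the 5-isopropyl-1,2,4-oxadiazol-3-yl group, an aromatic ring on the carbonyl carbon fits this place on the ring nitrogen: this assay shows a number 32 percentage points higher from compound 3 to compound 4 (beyond the scatter), and no change at the digits printed from compound 2 to compound 4 (within the scatter). Compound 1 remains apart, with a number 16 percentage points lower from compound 1 to compound 4 (beyond the scatter), so this aromatic ring matches the cyclobutylsulfanyl group but not the 1-cyano-1-methylethoxy group. No measured evidence here explains these steps. From the compounds shown here alone, compound 3 differs from compound 4 in both its thiocarbonyl and its three-membered ring group, so the effect of each alone stays open. Going by these compounds, how a phenyl ring or a simple amine on that carbonyl carbon would compare also stays open.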